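This account rests on a few compounds, and the source may have more. Where it says the series, first, only, none or still open, it means among the compounds named here.

Working notes on the series, read in an ADME assay on HeLa cells (Homo sapiens) for cytotoxicity, read by MTT assay, with a stated time of 2 days; a lower number here means that less compound is tolerated, a higher number that more compound is tolerated.

Compound 1 `CNC(=O)c1cc(Oc2ccc3c(C)c(C(=O)OC)sc3c2)ccn1`: 15700 nM
Compound 2 `CNC(=O)c1cc(Oc2ccc3c(C)c(C(=O)OC(C)C)sc3c2)ccn1`: 9600 nM

Going by the values given here, compound 2 stands within the scatter of the only other measured compound, so the two values do not separate. The next compound to be read is compound 3 `CCCOC(=O)c1sc2cc(Oc3ccnc(C(=O)NC)c3)ccc2c1C`. The structural change is propyl in place of isopropyl on an oxygen next to a carbonyl group. Among the compounds with values here, one measured step bears on this, made at the same place: a 1.6-fold lower number from compound 1 to compound 2 (0.21 log units; within the scatter), with isopropyl in place of methyl. That step gives no sign that this place moves the number in this assay, although no propyl group has been measured yet. No change beyond the scatter is therefore expected, and the estimated step is a 1.0-fold higher number from compound 2 to compound 3 (0.02 log units; within the scatter). The expected value for compound 3 is 10000 nM, with an estimated range from 5000 nM to 20000 nM.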

Compound 3, half-maximal cytotoxic concentration: 57100 nM
Compound 3: middle estimate off by 5.7-fold (0.76 log units), on the low side; measured number above the stated range.
By their numbers in this assay, from the lowest: compounds 2 and 1 (each within the scatter of the next); then compound 3.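

In this assay this position does move the number: propyl in place of isopropyl on an oxygen next to a carbonyl group gives a 5.9-fold higher number from compound 2 to compound 3 (0.77 log units; beyond the scatter) and so separates two groups that the earlier pair of compounds gave no reason to tell apart. Compound 3 also stands clear of the methyl compound, with a 3.6-fold higher number from compound 1 to compound 3 (0.56 log units; beyond the scatter) as the step, while isopropyl and propyl carry the same count of heavy atoms, so that count alone does not set the number here. Nothing at hand gives a reason for this step.

The compounds shown leave open whether the higher number belongs to a straight chain generally or to propyl alone, which an ethyl or butyl group on the same oxygen would address. As far as these compounds go, how a carboxylic acid in place of this group would read also stays open.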